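The source may hold more compounds than are shown below. What is called first, only, known or untested is meant among the compounds shown, and "the series" means these compounds.

Measured compounds in a functional assay on HT-29 cells (Homo sapiens) for cytotoxicity, read by MTT assay, with a stated time of 72 h; a higher number here means a weaker inhibitor, a lower number a stronger inhibitor:
compound 1, `CN(C)CCn1cnnc1-c1cc(Oc2ccc(NC(=O)N/N=C/c3ccc(F)cc3Cl)cc2F)ccn1`, gives 510 nM
compound 2, `CN(C)CCn1cnnc1-c1cc(Oc2ccc(NC(=O)N/N=C/c3cccc(Cl)c3Cl)cc2F)ccn1`, gives 130 nM
compound 3, `COc1ccc(/C=N/NC(=O)Nc2ccc(Oc3ccnc(-c4nncn4CCN(C)C)c3)c(F)c2)cc1O`, gives 960 nM

Compound 1 stands second highest of the three numbers. Its nearest neighbour is compound 3, reached by a 1.9-fold higher number from compound 1 to compound 3 (0.27 log units; within the scatter); its furthest is compound 2, reached by a 3.9-fold lower number from compound 1 to compound 2 (0.59 log units; beyond the scatter). Compound 2 to compound 3 is the larger move: a 7.4-fold higher number from compound 2 to compound 3 (0.87 log units; beyond the scatter).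

Compound 4, `COc1cc(/C=N/NC(=O)Nc2ccc(Oc3ccnc(-c4nncn4CCN(C)C)c3)c(F)c2)ccc1O`, is not yet measured. Relative to compound 1 the change is 4-hydroxy-3-methoxyphenyl in place of 2-chloro-4-fluorophenyl on a carbon with a double bond to nitrogen.

The step that bears on this is the move from compound 1 to compound 3, where the entering group is the other hydroxy-methoxy arrangement on the same carbon; that step stayed within the scatter. Going by the values given here, no measured pair separates the 4-hydroxy-3-methoxyphenyl from the 3-hydroxy-4-methoxyphenyl, so the expectation for compound 4 rests on compound 3 behaving as the closest analogue. For compound 4 the expected step in this assay is a 1.8-fold higher number from compound 1 to compound 4 (0.25 log units; within the scatter), a small rise in the number that may well sit within the scatter. Compound 4 is therefore estimated at 900 nM, with a range of 400 nM to 2200 nM.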

Compound 4, half-maximal inhibitory concentration: 120 nM
For compound 4 the middle estimate is 7.5-fold (0.88 log units) above the measured one, and the stated range ends above it.
By their numbers in this assay, from the lowest: compounds 4 and 2 (each within the scatter of the next); then compounds 1 and 3 (each within the scatter of the next).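

In this assay the placement of the hydroxy and methoxy groups on this carbon with a double bond to nitrogen matters: an 8.0-fold lower number from compound 3 to compound 4 (0.90 log units; beyond the scatter) separates the 3-hydroxy-4-methoxyphenyl from the 4-hydroxy-3-methoxyphenyl, so one arrangement cannot stand in for the other. Compound 3 alone suggested that this exchange for the 2-chloro-4-fluorophenyl changed little, yet a 4.3-fold lower number from compound 1 to compound 4 (0.63 log units; beyond the scatter) is read beyond the scatter for the other arrangement. With a 1.1-fold lower number from compound 2 to compound 4 (0.03 log units; within the scatter) inside the scatter, an oxygen-bearing ring and the 2,3-dichlorophenyl ring now share one range of numbers, so halogens are not required at this place.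

Going by these compounds, whether a 4-hydroxyphenyl without the methoxy, or a 4-amino-3-methoxyphenyl, would keep this number remains open. No supporting data are available to account for the gap between the two hydroxy-methoxy arrangements.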